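Phenyl in Place of Cyanopyridyl: An Estimate for Compound 4

The compounds below may be only part of what the source reports. "The series", "measured", "known", "first", "only" and "open" are said of these compounds alone.

Compounds measured in a functional assay on BJAB cells (Homo sapiens) for antiproliferative activity, with a stated time of 4 days; a higher number here means that more compound is needed for the effect, a lower number that less compound is needed:
Compound 1, `Cc1c(-c2cc(Cl)cc(Cl)c2)c(C(=O)O)nn1-c1nc(-c2cc(Cl)ccc2F)c(SC(C)C)s1`, gives 4800 nM.
Compound 2, `Cc1nn(-c2nc(-c3ccc(Cl)c(Cl)c3)c(SC(C)C)s2)c(C(=O)O)c1-c1cncc(C#N)c1`, gives 20000 nM.
Compound 3, `Cc1nn(-c2nc(-c3ccc(Cl)c(Cl)c3)c(SC(C)C)s2)c(C(=O)O)c1-c1cccnc1`, gives 12000 nM.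

Compound 2 stands highest of these numbers; compound 3 lies nearest, with a 1.7-fold lower number from compound 2 to compound 3 (0.22 log units; within the scatter), and compound 1 lies furthest, beyond the scatter. The unmeasured compound 4, `Cc1nn(-c2nc(-c3ccc(Cl)c(Cl)c3)c(SC(C)C)s2)c(C(=O)O)c1-c1ccccc1`, differs from compound 2 by phenyl in place of 5-cyanopyridin-3-yl on an aromatic carbon. Among the compounds with values here, only one measured step bears on this change, a 1.7-fold lower number from compound 2 to compound 3 (0.22 log units; within the scatter), which removes the cyano alone. The further loss of the ring nitrogen has no measured counterpart among these compounds. For compound 4 a small lowering of the order of that step is therefore expected, a 2.0-fold lower number from compound 2 to compound 4 (0.30 log units; within the scatter), with wide uncertainty. Compound 4 is estimated at 10000 nM, within 4000 nM to 25000 nM.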

Compound 4, half-maximal effective concentration: 3000 nM
Compound 4: middle estimate off by 3.3-fold (0.52 log units), on the high side, and the stated range ends above it.
By their numbers in this assay, from the lowest: compounds 4 and 1 (each within the scatter of the next); then compounds 3 and 2 (each within the scatter of the next).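

In this assay, the change from pyridin-3-yl to phenyl gives a 4.0-fold lower number from compound 3 to compound 4 (0.60 log units; beyond the scatter), so at this position the ring nitrogen counts for more than the cyano, whose removal alone stayed within the scatter. The whole change from 5-cyanopyridin-3-yl to phenyl gives a 6.7-fold lower number from compound 2 to compound 4 (0.82 log units; beyond the scatter). No measurement at hand explains this difference. As far as these compounds go, whether an amine or a methoxy group on the phenyl would keep the lower number remains open. So does whether the same change would carry over to the core of compound 1.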